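A few compounds are considered here, and "the series" means these few. Any claim that something is new, unique, unknown or untested is made for them only; others in the source may bear on it.

In a functional assay on COLO 205 cells (Homo sapiens) for inhibition, read by sulforhodamine B assay (on this read-out lower numbers stand for stronger inhibition of growth and higher numbers for weaker inhibition of growth), compound 1 (`Clc1cccc(-c2ccc(-c3ccc(-c4nc5ccccc5[nH]4)cc3)cc2)c1`) gives 100000 nM and compound 2 (`Oc1cccc2[nH]c(-c3ccc(-c4ccc(-c5ccc(C(F)(F)F)cc5)cc4)cc3)nc12`) gives 3410 nM while compound 3 (`COc1ccc(-c2ccc(-c3ccc(-c4nc5c(O)cccc5[nH]4)cc3)cc2)cc1`) stands lowest of the three at 1630 nM on this scale. Compound 4 (`Oc1cccc2[nH]c(-c3ccc(-c4ccc(-c5cccc(Cl)c5)cc4)cc3)nc12`) differs from compound 3 by one change, 3-chlorophenyl in place of 4-methoxyphenyl on an aromatic carbon. For the measured compounds named here, the one measured step that exchanges a group at this place is a 2.1-fold lower number from compound 2 to compound 3 (0.32 log units; beyond the scatter) and it is modest, with methoxy in place of trifluoromethyl. The 3-chlorophenyl also occurs in compound 1, but that compound lacks the hydroxyl of the others, so the data cannot separate the two features. Starting from compound 3 at 1630 nM and given the modest size of a 2.1-fold lower number from compound 2 to compound 3 (0.32 log units; beyond the scatter) a moderately higher number is expected in this assay rather than a collapse. The expected step is a 2.1-fold higher number from compound 3 to compound 4 (0.33 log units; beyond the scatter) and it remains an estimate. Compound 4 is estimated at 3500 nM (1200 nM to 15000 nM).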

Compound 4, concentration for 50% growth inhibition: 8600 nM
Compound 4: middle estimate off by 2.5-fold (0.39 log units), on the low side, within the range that was stated.
By their numbers in this assay, from the lowest: compound 3; then compound 2; then compound 4; then compound 1.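

In this assay, the exchange of 4-methoxyphenyl for 3-chlorophenyl gives a 5.3-fold higher number from compound 3 to compound 4 (0.72 log units; beyond the scatter), and the exchange of 4-(trifluoromethyl)phenyl for 3-chlorophenyl gives a 2.5-fold higher number from compound 2 to compound 4 (0.40 log units; beyond the scatter), so 3-chlorophenyl stands with the highest number of the three groups compared at this position on the hydroxyl-bearing core. For the compounds shown here, the hydroxyl can now be read apart from the 3-chlorophenyl: hydroxy in place of hydrogen gives a 12-fold lower number from compound 1 to compound 4 (1.07 log units; beyond the scatter), a large step that the earlier compounds could not isolate. Nothing available accounts for either change.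

The 3-chlorophenyl exchange alters both the substituent and where it sits on this phenyl, and no pair shown separates the two. Going by these compounds, whether an amine or a carboxylic acid on this ring would be tolerated, and whether the hydroxyl step holds with other aryl groups, stays open.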